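The compounds below may be only part of what the source reports. "The series", "measured", "known", "first", "only" and "open" are said of these compounds alone.

Three compounds share one core and differ only in the amine attached to a thiocarbonyl carbon. Compound 1 `Nc1ccccc1NC(=O)c1ccc(CSC(=S)N2CCN(Cc3ccccn3)CC2)cc1` carries a piperazine ring bearing a pyridinylmethyl group, compound 2 `CC1CCN(C(=S)SCc2ccc(C(=O)Nc3ccccc3N)cc2)CC1` carries a 4-methylpiperidin-1-yl group, and compound 3 `Nc1ccccc1NC(=O)c1ccc(CSC(=S)N(Cc2ccccc2)Cc2ccccc2)cc1` carries two benzyl groups on the nitrogen. In a functional assay on HeLa cells (Homo sapiens) for antiproliferative activity, read by CCK-8 assay, with a stated time of 72 h, tested at 8 uM (on this read-out higher numbers stand for a stronger effect at the one concentration tested and lower numbers for a weaker effect), compound 1 gives 61.4%, compound 2 gives 72.5%, and compound 3 gives 18.9%. Compound 2 thus stands highest of the three, with compound 1 nearest, at a number beyond the usual scatter below it, and compound 3 furthest, at a number far below it.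

Compound 4 `Nc1ccccc1NC(=O)c1ccc(CSC(=S)N2CCc3ccccc32)cc1` has not been measured in this assay. It differs from compound 2 in one place: 2,3-dihydro-1H-indol-1-yl in place of 4-methylpiperidin-1-yl on a thiocarbonyl carbon. The new group keeps a ring on the nitrogen, as in compound 2, but adds an aromatic ring, as in compound 3. The step is expected to go downward beyond the scatter, a number 22.5 percentage points lower from compound 2 to compound 4 (beyond the scatter), because compound 3 with its aromatic groups gives only 18.9%. Compound 4 is therefore estimated to give 50%, in a range from 25% to 72%.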

Compound 4, a percentage reported as inhibition, at one concentration (the size of the read-out at that concentration, not a potency): 67%
The estimate for compound 4 lay 17 percentage points below the measured number, within the range that was stated.
By their numbers in this assay, from the lowest: compound 3; then compounds 1, 4 and 2 (each within the scatter of the next, the first and the last beyond it).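

In this assay, 2,3-dihydro-1H-indol-1-yl in place of 4-methylpiperidin-1-yl on a thiocarbonyl carbon gives a number 5.5 percentage points lower from compound 2 to compound 4 (within the scatter), so no change can be read from this swap. An aromatic ring in the amine therefore does not by itself go with a low number: compound 4 carries one and gives 67% in this read-out, while compound 3, with its two benzyl groups, gives 18.9% on the same scale. Nothing available explains why the two ring groups read alike.

The compounds shown leave open how a morpholine ring or a dimethylamino group would read at this place. They also leave open whether an amine bearing one benzyl group and one methyl group would read closer to compound 3 or to compound 4.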